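A few compounds are considered here, and "the series" means these few. Any claim that something is new, unique, unknown or untested is made for them only; others in the source may bear on it.

Compound 1 `Cc1ccc(NC(=O)C[C@H](CCC(=O)O)c2noc(-c3ncc(CC(C)C)o3)c2C2CC2)c(Cl)c1`: 75%
Compound 2 `Cc1ccc(NC(=O)C[C@H](CCC(=O)O)c2noc(-c3cnc(CC(C)C)s3)c2C2CC2)c(Cl)c1`: 54%

Within the data shown here, in an ADME assay on microsomes from liver (Homo sapiens) for metabolic stability, with a stated time of 60 min (a higher number here means that more of the compound is left, a lower number that less of the compound is left), compound 2 gives 54%, the lower of the two numbers so far. Compound 3 `Cc1ccc(NC(=O)C[C@H](CCC(=O)O)c2noc(-c3cc(CCC(C)C)on3)c2C2CC2)c(Cl)c1` differs from it in one place: 5-isopentyl-1,2-oxazol-3-yl in place of 2-isobutyl-1,3-thiazol-5-yl on an aromatic carbon. Among the measured compounds shown here, only one measured step bears on this change, a modest one: a number 21 percentage points lower from compound 1 to compound 2 (beyond the scatter). It is a loose guide, since the entering 5-isopentyl-1,2-oxazol-3-yl shares with the group in compound 1 only a ring oxygen in place of sulfur. A partial recovery is therefore expected, with an estimated a number 8 percentage points higher from compound 2 to compound 3 (within the scatter). For compound 3 the expected value is 62%, with an estimated range from 40% to 80%.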

Compound 3, percent of the compound remaining: 79%
For compound 3 the middle estimate is 17 percentage points below the measured one, within the range that was stated.
By their numbers in this assay, from the lowest: compound 2; then compounds 1 and 3 (each within the scatter of the next).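

In this assay, 5-isopentyl-1,2-oxazol-3-yl in place of 2-isobutyl-1,3-thiazol-5-yl gives a number 25 percentage points higher from compound 2 to compound 3 (beyond the scatter), so the loss seen with the thiazole group does not extend to every five-membered aromatic ring at this position. Between the two oxygen-containing groups, the result is a number 4 percentage points higher from compound 1 to compound 3 (within the scatter), so this different ring and longer chain leave no readable change. No measurement here explains why the thiazole group stands apart. Ring and chain change together in these steps, so their separate contributions remain open. An isopentyl chain on the 1,3-thiazol-5-yl ring, or an isobutyl chain on the 1,2-oxazol-3-yl ring, would pull them apart.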